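Swapping the triazolylmethyl group of compound 2 on the shared core

The source may hold more compounds than are shown below. What is called first, only, known or untested is meant among the compounds shown, and "the series" means these compounds.

In a functional assay on SW480 cells (Homo sapiens) for antiproliferative activity, read by MTT assay, with a stated time of 48 h (a higher number here means a weaker inhibitor, a lower number a stronger inhibitor), compound 1 `CC(C)=CCC[C@]1(C)/C=C/[C@@H](OC(=O)C=C(C)C)[C@](C)(O)/C=C/C(=O)/C(C(=O)O)=C\C1` gives > 10000 nM as a limit of the assay and not a number. Going by the values given here, compound 2 `CC(C)=CCC[C@]1(C)/C=C/[C@@H](OC(=O)C=C(C)C)[C@](C)(O)/C=C/C(=O)/C(Cn2cc(CO)nn2)=C\C1` reads 2870 nM in this assay and so holds the only true number so far. Among the compounds with values here, the one measured step, an at least 3.4-fold lower number from compound 1 to compound 2 (0.54 log units; beyond the scatter) on putting (4-(hydroxymethyl)-1H-1,2,3-triazol-1-yl)methyl in place of carboxy, shows that the read-out responds to the group at this place.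

Compound 3 `CO/N=C/C1=C/C[C@](C)(CCC=C(C)C)/C=C/[C@@H](OC(=O)C=C(C)C)[C@](C)(O)/C=C/C1=O` has not yet been measured. Compared with compound 2, compound 3 carries this change: a group of 4 heavy atoms (2 carbon, 1 nitrogen, 1 oxygen; no ring) in place of a group of 8 heavy atoms (4 carbon, 3 nitrogen, 1 oxygen; one five-membered aromatic ring with 3 hetero atoms), on a double-bonded ring carbon and the rest of the core stays the same. The step from compound 1 involves neither the entering group nor the loss of the triazole, so it gives no direction for this change. With compound 2 at 2870 nM as the only anchor, no step beyond the scatter is expected in this assay for now, though a move either way remains possible.

The expected change is a 1.0-fold higher number from compound 2 to compound 3 (0.02 log units; within the scatter) on present data. For compound 3 the estimated value is 3000 nM within an expected range of 900 nM to 10000 nM in this assay.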

Compound 3, half-maximal inhibitory concentration: 2630 nM
Beside the measured number, compound 3's estimate is 1.1-fold (0.06 log units) above it, within the range that was stated.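

Exchanging the (4-(hydroxymethyl)-1H-1,2,3-triazol-1-yl)methyl group for the smaller group with no ring gives a 1.1-fold lower number from compound 2 to compound 3 (0.04 log units; within the scatter) in this assay, so at this place on the double-bonded ring carbon the read-out does not require the five-membered aromatic ring or the hydroxy group it carries. The group with no ring also gives an at least 3.8-fold lower number from compound 1 to compound 3 (0.58 log units; beyond the scatter), so two quite different groups now separate from the carboxy compound, and the earlier step can no longer be tied to the triazole alone. The size of both steps away from compound 1 stays open-ended, as compound 1 stands at a limit and not a number: the limit of > 10000 nM in this assay, at which 1 of the 3 values shown sits.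

The compounds shown leave open whether the carboxylic acid is itself what costs the activity or whether the two entering groups each add something, and a plain methyl, an amine or a longer chain at this place would help separate these readings. They also leave open whether any group here can take the number clearly beyond the level that compound 2 and compound 3 share.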